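This account rests on a few compounds, and the source may have more. Where it says the series, first, only, none or still open, it means among the compounds named here.

In a functional assay on HL-60 cells (Homo sapiens) for antiproliferative activity, read by MTT assay, with a stated time of 48 h (a lower number here means a stronger inhibitor, a higher number a weaker inhibitor), compound 1 `CCN(CC)CCn1c(N)c(-c2nc3ccccc3[nH]2)c2nc(C#N)c(C#N)nc21` gives 1880 nM. Compound 3 `N#Cc1nc2c(-c3nc4ccccc4[nH]3)c(N)n(CCCN3CCCCC3)c2nc1C#N` gives 1680 nM, which is a 1.1-fold lower number from compound 1 to compound 3 (0.05 log units; within the scatter). Compound 2 `CN(C)CCCn1c(N)c(-c2nc3ccccc3[nH]2)c2nc(C#N)c(C#N)nc21` gives 870 nM, which is a 2.2-fold lower number from compound 1 to compound 2 (0.33 log units; beyond the scatter), so compound 1 stands level with compound 3 and apart from compound 2. The step to compound 4 `CCN(CC)CCn1c(N)c(-c2nc3cc(Cl)ccc3[nH]2)c2nc(C#N)c(C#N)nc21` leaves the side chain alone: chloro in place of hydrogen on an aromatic carbon. Among the compounds with values here, all the measured steps alter the amine on the chain, and none touches this carbon, so they offer only a scale, the largest being a 2.2-fold lower number from compound 1 to compound 2 (0.33 log units; beyond the scatter). No step beyond the scatter is therefore expected in this assay. The expected change is a 1.3-fold lower number from compound 1 to compound 4 (0.10 log units; within the scatter). Compound 4 is estimated at 1500 nM, within a range of 600 nM to 3500 nM.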

Compound 4, half-maximal inhibitory concentration: > 50000 nM
Compound 4: no number, only a limit (the forecaster's own chance of this, stated with the estimate: 3%); middle value at least 33-fold (1.52 log units) away from the limit.
By their numbers in this assay, from the lowest: compounds 2, 3 and 1 (each within the scatter of the next, the first and the last beyond it). At a limit, above all of these: compound 4.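

Compound 4 carries a limit of the assay and not a number: the limit of > 50000 nM in this assay, at which 1 of the 4 values shown sits. In this assay, the single chloro of the 5-chloro-1H-benzimidazol-2-yl group gives an at least 26-fold higher number from compound 1 to compound 4 (1.42 log units; beyond the scatter), a larger step than any made by changing the amine on the chain. This aromatic carbon therefore shows a sensitivity that the amine changes did not reveal. Going by these compounds, it remains open whether fluoro, methyl or methoxy at this carbon would give the same loss. Also open, on these data alone, is whether the dimethylamino chain of compound 2 would behave the same way with chloro present.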